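Lengthening the aryl ether in a cyclopropane hydrazide pair

The source may report more compounds than this note shows. Statements on the series, on what has been measured and on what is new or still open speak of the compounds shown alone.

Measured compounds:
Compound 1 `O=C(NNC(=O)C1CC1c1ccc(OC(F)(F)F)cc1)c1ccncc1`: in a functional assay on PC-3 cells (Homo sapiens) for inhibition, read by MTT assay, with a stated time of 72 h (a lower number here means a stronger inhibitor, a higher number a weaker inhibitor), compound 1 reached only the assay limit, > 100000 nM.
Compound 2 `COc1ccc(C2CC2C(=O)NNc2nncc3ccccc23)cc1`: in this assay compound 2 gave 64000 nM.

Within the data shown here, compound 2 carries the only number in this set; it is a weak inhibitor on its own, and nothing else here is stronger or weaker in a measurable way. The value for compound 1 is not a number but a limit, (the limit of > 100000 nM in this assay, at which 1 of the 2 values shown sits). Among the measured compounds shown here, no pair of measured compounds differs in a single place, so no measured step is available to guide the next comparison.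

Compound 3 `CC(C)=CCOc1ccc(C2CC2C(=O)NNc2nncc3ccccc23)cc1` is the unmeasured partner of compound 2. The change reads (2-methylprop-1-en-1-yl in place of hydrogen on a saturated chain carbon bound to an oxygen on an aromatic ring), leaving the hydrazide and the rest of the shared core untouched.

For the measured compounds named here, with no measured step of this kind, one expects only a small step in this assay, leaning towards stronger inhibition but possibly not beyond the scatter, and the expected step is a 2.1-fold lower number from compound 2 to compound 3 (0.33 log units; beyond the scatter). One therefore estimates compound 3 at 30000 nM, with a range from 8000 nM to 120000 nM, while noting a fair chance that the assay returns only a limit.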

Compound 3, half-maximal inhibitory concentration: 81000 nM
Compound 3: the middle estimate sits 2.7-fold (0.43 log units) below what was measured, within the range that was stated.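

In this assay, among these compounds, this step gives the first reading at this position: 2-methylprop-1-en-1-yl in place of hydrogen on a saturated chain carbon bound to an oxygen on an aromatic ring, which turns methoxy into (3-methylbut-2-en-1-yl)oxy, gives a 1.3-fold higher number from compound 2 to compound 3 (0.10 log units; within the scatter). The two compounds therefore cannot be told apart in this assay, so this one pair shows that the position takes the added chain of 4 carbon atoms with its double bond and no difference beyond the scatter, though it offers no gain in inhibition. The set as a whole still gives little room for comparison, and one of its three values is not a number: the limit of > 100000 nM in this assay, at which 1 of the 3 values shown sits.

What the compounds leave open is whether a different kind of group at this position, such as a chain ending in an amine or a carboxylic acid, would move the number beyond the scatter in either direction. Compound 1 stands only as a limit and differs from the others in more than one place, so any steps to it cannot be read and the part played by the rest of the structure remains undecided.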